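The compounds below may be only part of what the source reports. "The series", "measured", "known", "first", "only" and "open" are said of these compounds alone.

Working notes on the series. In a functional assay on MCF7 cells (Homo sapiens) for antiproliferative activity, read by MTT assay, with a stated time of 72 h (on this read-out lower numbers stand for stronger inhibition and higher numbers for weaker inhibition), compound 1 `CCOC(=O)c1oc2ccc(NS(=O)(=O)c3ccccc3Cl)cc2c1C` gives only a limit, > 200000 nM, which is not a number. In this assay compound 2 `CCOC(=O)c1oc2ccc(NS(=O)(=O)c3ccccc3[N+](=O)[O-])cc2c1C` gives 157000 nM. Within the data shown here, the step of an at least 1.2-fold lower number from compound 1 to compound 2 (0.10 log units; that floor lies within the scatter) is the sole measured step, and it rests on (the limit of > 200000 nM in this assay, at which 1 of the 2 values shown sits), so it sets no more than a floor. Among the measured compounds shown here, compound 2 thus stands as the only compound in the set with a numeric value; the single other entry is a limit.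

Compound 3 `CCOC(=O)c1oc2ccc(NS(=O)(=O)c3cccs3)cc2c1C` differs from compound 2 by thiophen-2-yl in place of 2-nitrophenyl on a sulfonyl sulfur. For the measured compounds named here, no measured step matches this change: the step from compound 1 to compound 2 exchanges one group on an aromatic carbon for another and keeps the six-membered aromatic ring, whereas here the whole ring on the sulfonyl sulfur is replaced. That measured step was small and bounded by a limit, so nothing measured supports a shift beyond the scatter in either direction. For compound 3 no shift beyond the scatter is expected, an estimated step of a 1.2-fold higher number from compound 2 to compound 3 (0.08 log units; within the scatter). Compound 3 is expected at 190000 nM, within a range of 90000 nM to 400000 nM, with a real chance that this assay again reports only a limit.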

Compound 3, half-maximal inhibitory concentration: 92300 nM
Compound 3: the middle estimate sits 2.1-fold (0.31 log units) above what was measured, within the range that was stated.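

The ring on the sulfonyl sulfur can be replaced outright in this assay: with thiophen-2-yl in place of 2-nitrophenyl the series shows a 1.7-fold lower number from compound 2 to compound 3 (0.23 log units; within the scatter), so a five-membered aromatic ring with 1 hetero atom also gives a numeric value, and this exchange cannot be told apart from the scatter. Set against the 2-chlorophenyl group, thiophen-2-yl gives an at least 2.1-fold lower number from compound 1 to compound 3 (0.33 log units; beyond the scatter), the only step in the series so far that lies beyond the scatter. That step is a floor and its true size cannot be read, because it rests on a limit and not on a number: the limit of > 200000 nM in this assay, at which 1 of the 3 values shown sits.

Still open, on these data alone, is whether any ring on the sulfonyl sulfur is needed at all, which a methyl group, a longer alkyl chain or a thiophene ring carrying an amine in that place would begin to answer. Equally open, as far as these compounds go, is whether a change elsewhere, such as a carboxylic acid in place of the ethyl ester on the shared core, would move compound 3 far from 92300 nM.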